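LRRK2 series: amide benzyl ethers, spirocyclic amine replacement

The source may hold more compounds than are shown below. What is called first, only, known or untested is meant among the compounds shown, and "the series" means these compounds.

Measured compounds:
compound 1 `O=C(Nc1ccnnc1)c1cc(N2CCC(F)CC2)ccc1OCc1ccccc1`, 39.8 nM
compound 2 `O=C(Nc1cccnc1)c1cc(C(F)(F)F)ccc1OCc1ccccc1`, 12.6 nM

Both compounds were measured in an assay on Sf9 cells for inhibition of Leucine-rich repeat serine/threonine-protein kinase 2 (Homo sapiens), read by TR-FRET, with stated times of 30 min and 2 h; a lower number here means a stronger inhibitor, a higher number a weaker inhibitor. Compound 1 gives 39.8 nM and stands with the highest number of the two; compound 2, with 12.6 nM, lies a step below it that goes beyond the scatter. The two differ in more than one place, so their values are taken only as they stand.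

Compound 3 `CN1CC2(CCN(c3ccc(OCc4ccccc4)c(C(=O)Nc4ccnnc4)c3)CC2)C1` has not yet been measured in this assay. It differs from compound 1 in one place:
a group of 10 heavy atoms (8 carbon, 2 nitrogen; one four-membered non-aromatic ring with 1 hetero atom, one six-membered non-aromatic ring with 1 hetero atom) in place of a group of 7 heavy atoms (5 carbon, 1 nitrogen, 1 fluorine; one six-membered non-aromatic ring with 1 hetero atom), on an aromatic carbon
The change sits on an aromatic carbon, meta to the (pyridazin-4-yl)carbamoyl group and para to the benzyloxy group. Within the data shown here, no measured pair in the set shows the same change, so its size is not known. The step of a 1.3-fold lower number from compound 1 to compound 3 (0.12 log units; within the scatter) is expected to stay within the scatter, with no clear direction. For compound 3 the estimate in this assay is 30 nM, with a range from 8 nM to 100 nM.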

Compound 3, half-maximal inhibitory concentration: 63.1 nM
Compound 3: middle estimate off by 2.1-fold (0.32 log units), on the low side; the range from low to high includes it.
By their numbers in this assay, from the lowest: compound 2; then compounds 1 and 3 (each within the scatter of the next).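

In this assay the group with a four-membered and a six-membered non-aromatic ring, put in place of 4-fluoropiperidin-1-yl on the aromatic carbon para to the benzyloxy group, gives a 1.6-fold higher number from compound 1 to compound 3 (0.20 log units; within the scatter) and so cannot be told apart from the parent reading. This one pair shows that, in the core of compound 1, the position takes a larger group with an extra ring and no fluorine without a step beyond the scatter. No supporting measurement accompanies the step, so nothing can be said about why the reading holds.

Among these compounds, the single pair cannot separate the loss of fluorine from the gain of the second ring, which plain piperidin-1-yl or morpholin-4-yl at this carbon would address. Going by these compounds, an open-chain dimethylamino group at the same carbon also remains open, as does trifluoromethyl there with the (pyridazin-4-yl)carbamoyl group kept in place.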